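A few compounds are considered here, and "the series" means these few. Any claim that something is new, unique, unknown or untested is made for them only; others in the source may bear on it.

For the measured compounds named here, in an ADME assay on MDCKII-LE cells (Canis lupus familiaris) for permeability (a lower number here means that the compound crosses the layer more slowly, a higher number that the compound crosses the layer faster), three related amides have numbers so far. Compound 1 (`Cc1cnc(NC(=O)c2cc(Oc3ccc(C(=O)N(C)C)nc3)c3cc(C)oc3c2)cn1`) gives 28.5 10^-6 cm/s and compound 2 (`Cc1ccc(Oc2cc(C(=O)Nc3cnc(C)cn3)cc3oc(C)cc23)cc1`) gives 0.3 10^-6 cm/s while compound 3 (`Cc1ccc(NC(=O)c2cc(Oc3cnc(C(=O)N(C)C)cn3)c3cc(C)oc3c2)nc1`) gives 21.5 10^-6 cm/s as its reading. Compound 3 thus stands within the usual scatter of compound 1, and the values of both lie far above that of compound 2.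

Going by the values given here, compound 4 (`CCc1cnc(NC(=O)c2cc(Oc3cnc(C(=O)N(C)C)cn3)c3cc(C)oc3c2)cn1`) differs from compound 3 at one place, on an amide-type nitrogen, where 5-ethylpyrazin-2-yl stands in place of 5-methylpyridin-2-yl (5-ethylpyrazin-2-yl in place of 5-methylpyridin-2-yl on an amide-type nitrogen) as the single change. Among the compounds with values here, no measured pair isolates this change. Within the data shown here, the only guide is that compound 1 at 28.5 10^-6 cm/s and compound 3 at 21.5 10^-6 cm/s remain within the scatter of each other despite their different structures. Compound 2 at 0.3 10^-6 cm/s shows that a much lower number is possible among these amides, so the expected range is kept wide.

The expected change is small, with a 1.1-fold lower number from compound 3 to compound 4 (0.05 log units; within the scatter) as the estimate, and no shift beyond the scatter is expected in this assay for this step. For compound 4 the estimated reading is 19 10^-6 cm/s with a likely span from 8 10^-6 cm/s to 35 10^-6 cm/s as the expected range.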

Compound 4, apparent permeability in the MDCKII-LE assay: 23.7 10^-6 cm/s
For compound 4 the middle estimate is 1.2-fold (0.10 log units) below the measured one, within the range that was stated.
By their numbers in the MDCKII-LE assay, from the lowest: compound 2; then compounds 3, 4 and 1 (each within the scatter of the next).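

For the compounds shown here, in the MDCKII-LE assay, the step gives the first direct reading at this position: replacing 5-methylpyridin-2-yl with 5-ethylpyrazin-2-yl on the amide-type nitrogen gives a 1.1-fold higher number from compound 3 to compound 4 (0.04 log units; within the scatter). In a physicochemical assay for solubility, measured as kinetic solubility (a lower number here means a less soluble compound, a higher number a more soluble compound), the same change gives a 1.8-fold lower number from compound 3 to compound 4 (0.26 log units; within the scatter), so this pair shows no shift beyond the scatter in either assay, with compound 3 at 215000 nM and compound 4 at 117000 nM. No measured evidence is available to explain these readings.

The single step changes both the ring, which goes from one hetero atom to two, and the alkyl group, which goes from methyl to ethyl, so the compounds shown do not separate the two differences and a smaller effect from one could be offset by the other. They also leave open whether the same tolerance would hold at this position for a ring carrying an amine, a carboxylic acid or a longer chain such as butyl in place of the ethyl, and whether it would extend to other cores.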